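Halogen and Alkyl Exchange on the Aryl Group of Compound 3

This account rests on a few compounds, and the source may have more. Where it says the series, first, only, none or still open, it means among the compounds named here.

Among the compounds with values here, the shared core of this set carries an aryl group on a ring nitrogen, and only that aryl group varies. Compound 1 `CCCCN(CC)c1cc(C)nc2c1NC(=O)CN2c1ccc(Br)cc1Br` bears a 2,4-dibromophenyl there; in an assay on HEK-293T cells for displacement of a labelled ligand from corticotropin-releasing factor receptor 2 (Homo sapiens), read by scintillation counting, with a stated time of 2 h, tested at 1 uM (on this read-out higher numbers stand for more inhibition at the one concentration tested (going by the name of the read-out) and lower numbers for less inhibition), compound 1 gives 9.4%. Compound 2 `CCCCN(CC)c1cc(C)nc2c1NC(=O)CN2c1ccc(Cl)cc1Cl` carries a 2,4-dichlorophenyl instead, and in this assay compound 2 gives 0.9%. The step of a number 8.5 percentage points lower from compound 1 to compound 2 (within the scatter) is the only measured one, and it is within the scatter, so the two halogens give no separable result. Compound 3 `CCCCN(CC)c1cc(C)nc2c1NC(=O)CN2c1ccc(Cl)cc1C`, with a 4-chloro-2-methylphenyl, has no number in this assay: for compound 3 the result is "not determined" (no result reported), so compound 3 stands nowhere on the numbers shown. Compound 4 `CCCCN(CC)c1cc(C)nc2c1NC(=O)CN2c1ccc(Br)cc1CC` differs from compound 3 by 4-bromo-2-ethylphenyl in place of 4-chloro-2-methylphenyl on a nitrogen on an aromatic ring in a ring. Within the data shown here, only the step from compound 1 to compound 2 bears on it, since it also swaps chlorine for bromine at the aryl group, and that step lies within the scatter; the exchange of methyl for ethyl has no measured counterpart. Given both measured compounds sit near the floor, compound 4 is expected to give a similarly small read-out in this assay, estimated at 5% with a range of -10% to 20%.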

Compound 4, a percentage reported as inhibition, at one concentration (the size of the read-out at that concentration, not a potency): 2.1%
The estimate for compound 4 lay 2.9 percentage points above the measured number; the measured number falls inside the stated range.
By their numbers in this assay, from the lowest: compounds 2, 4 and 1 (each within the scatter of the next).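

Within the data shown here, with compound 4, an alkyl group on this aryl group has a number for the first time, since compound 3 has none and no comparison with compound 3 can be read. In this assay the exchange of the dichloro pattern for 4-bromo-2-ethylphenyl gives a number 1.2 percentage points higher from compound 2 to compound 4 (within the scatter) and the exchange of a bromo group for ethyl on an aromatic carbon gives a number 7.3 percentage points lower from compound 1 to compound 4 (within the scatter) as its result. On a nitrogen on an aromatic ring in a ring, therefore, neither step separates ethyl from the halogens in these compounds, and no reason for this can be offered, as nothing measured here bears on the result.

The compounds shown leave open whether a methoxy group, an amine or a carboxylic acid on this aryl group, or a chain longer than ethyl, would give a read-out that stands clear of the scatter from these three values. They also leave open whether an unsubstituted phenyl or a pyridine ring in this place would differ from the aryl groups seen so far.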